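This account rests on a few compounds, and the source may have more. Where it says the series, first, only, none or still open, it means among the compounds named here.

Measured compounds:
compound 1, `c1ccc(Nc2nc3ccccc3o2)cc1`: 8910 nM
compound 2, `CCc1ccc(Nc2nc3ccccc3o2)cc1`: 1210 nM
compound 3, `Clc1ccc2oc(Nc3ccccc3)nc2c1`: 4500 nM

In an assay on isolated protein (strain Balb/c) for inhibition of Polyunsaturated fatty acid 5-lipoxygenase (Mus musculus), read by immunoassay, with a stated time of 20 min (a lower number here means a stronger inhibitor, a higher number a weaker inhibitor), compound 3 holds the second highest of the three numbers. Its nearest neighbour is compound 1, whose number lies within the scatter of it, while compound 2 sits well below both. Compound 4, `Cc1ccc2oc(Nc3ccccc3)nc2c1`, differs from compound 3 by methyl in place of chloro on an aromatic carbon. The closest measured step is the one in which chloro entered the same ring, a 2.0-fold lower number from compound 1 to compound 3 (0.30 log units; within the scatter), which stayed within the scatter; the larger step of a 7.4-fold lower number from compound 1 to compound 2 (0.87 log units; beyond the scatter) concerns the other ring and bears only loosely. An exchange of one small group for another at this carbon is therefore expected to give no step beyond the scatter, a 1.1-fold lower number from compound 3 to compound 4 (0.05 log units; within the scatter). Compound 4 is estimated at 4000 nM, with a range from 1500 nM to 11000 nM.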

Compound 4, half-maximal inhibitory concentration: 4600 nM
Compound 4: middle estimate off by 1.2-fold (0.06 log units), on the low side, and the stated range covers the measured number.
By their numbers in this assay, from the lowest: compound 2; then compounds 3, 4 and 1 (each within the scatter of the next).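

In this assay, exchanging chloro for methyl on this aromatic carbon gave a 1.0-fold higher number from compound 3 to compound 4 (0.01 log units; within the scatter), and setting methyl in place of hydrogen there gave a 1.9-fold lower number from compound 1 to compound 4 (0.29 log units; within the scatter). Where the earlier compounds offered only chloro at this carbon, two different single-atom groups now leave the number within the scatter of the unsubstituted compound 1. No measurement shown offers an explanation for this.

As far as these compounds go, whether a longer chain, an amine or a carboxylic acid on this carbon would also stay within the scatter remains open. So does whether ethyl on the other ring would combine with methyl or chloro here.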